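The source may report more compounds than this note shows. Statements on the series, on what has been measured and on what is new or still open speak of the compounds shown alone.

Compound 1 `C=C1C(=O)[C@]23C[C@@]1(O)CC[C@H]2c1ccc(O)c(C)c1[C@@H]3Cn1cc(-c2ccccc2)nn1` and compound 2 `C=C1C(=O)[C@]23C[C@@]1(O)CC[C@H]2c1ccc(O)c(C)c1[C@@H]3Cn1cc(-c2ccc(F)cc2)nn1` share one core. In a functional assay on SW480 cells (Homo sapiens) for cytotoxicity, read by MTT assay, with a stated time of 4 days (a higher number here means a weaker inhibitor, a lower number a stronger inhibitor), compound 1 gives 260 nM, and compound 2 gives 250 nM. The change between them is fluoro in place of hydrogen on an aromatic carbon, and it made a step of a 1.0-fold lower number from compound 1 to compound 2 (0.02 log units; within the scatter). Compound 3 `C=C1C[C@]23C[C@@]1(O)CC[C@@H]2c1cccc(C)c1[C@@H]3Cn1cc(-c2ccccc2)nn1` is built on a different core; the difference between the two cores is not broken down here. In this assay compound 3 gives > 20000 nM, which is a limit of the assay rather than a number, the limit described as the limit of > 20000 nM in this assay, at which 1 of the 3 values shown sits. Compound 4 `C=C1C[C@]23C[C@@]1(O)CC[C@@H]2c1cccc(C)c1[C@@H]3Cn1cc(-c2ccc(F)cc2)nn1` has not yet been measured in this assay. Going by the values given here, it differs from compound 3 by fluoro in place of hydrogen on an aromatic carbon, the same change, at the same place, as the one between compound 1 and compound 2. Compound 4 is expected to move by a step that the limit leaves unreadable from compound 3 to compound 4, an expectation that rests on a 1.0-fold lower number from compound 1 to compound 2 (0.02 log units; within the scatter) for this same change. Compound 4 is therefore estimated at 25000 nM in this assay, most likely again reported only as a limit, with an expected range from 10000 nM to 60000 nM.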

Compound 4, half-maximal inhibitory concentration: > 20000 nM
Compound 4 ended at the assay's limit; the forecaster's own chance of this, stated with the estimate: 85%; the middle value does not contradict the limit.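

In this assay, compound 3 and compound 4 both sit at the same limit of the assay rather than at a number, so no step between them can be read: the limit of > 20000 nM in this assay, at which 2 of the 4 values shown sit.

The compounds shown leave open whether fluoro in place of hydrogen changes anything on the core of compound 3.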